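This account rests on a few compounds, and the source may have more. Where it says the series, first, only, none or still open, it means among the compounds named here.

The measurements come from a functional assay on MKN-74 cells (Homo sapiens) for antiproliferative activity, with a stated time of 24 h; a higher number here means a weaker inhibitor, a lower number a stronger inhibitor.
Compound 1 `COc1ccccc1NC(=S)N1CCc2c(sc(NC(=O)c3ccccc3Cl)c2C(N)=O)C1` gives 35200 nM.
Compound 2 `NC(=O)c1c(NC(=O)c2ccccc2I)sc2c1CCN(C(=S)Nc1ccccc1Br)C2` gives 22400 nM.
Compound 3 `NC(=O)c1c(NC(=O)c2ccccc2I)sc2c1CCN(C(=S)Nc1ccccc1C(F)(F)F)C2` gives 14200 nM.

Among these three numbers compound 3 stands lowest; compound 2 sits close to it, within the usual scatter, while compound 1 lies further off, beyond the scatter. Among the compounds with values here, the only single-point step measured, a 1.6-fold lower number from compound 2 to compound 3 (0.20 log units; within the scatter), changes the group at the same place that is now in question and stays within the scatter. Compound 4 `COc1ccccc1NC(=S)N1CCc2c(sc(NC(=O)c3ccccc3I)c2C(N)=O)C1` differs from compound 3 by methoxy in place of trifluoromethyl on an aromatic carbon. Within the data shown here, no measured pair isolates methoxy against trifluoromethyl. Compound 1, which carries the methoxy group, gives 35200 nM, a number beyond the scatter above compound 3, but compound 1 also differs from compound 3 elsewhere in the structure, so its gap cannot be credited to the methoxy group alone. Compound 4 is therefore expected to show a modest upward step of a 1.8-fold higher number from compound 3 to compound 4 (0.25 log units; within the scatter). The estimate for compound 4 is 25000 nM, with a range from 10000 nM to 60000 nM.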

Compound 4, half-maximal inhibitory concentration: 41800 nM
Compound 4: middle estimate off by 1.7-fold (0.22 log units), on the low side; measured number inside the range.
By their numbers in this assay, from the lowest: compounds 3, 2, 1 and 4 (each within the scatter of the next, the first and the last beyond it).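

In this assay, within the data shown here, methoxy in place of trifluoromethyl on the aromatic carbon ortho to a large group now has a measured pair, and a 2.9-fold higher number from compound 3 to compound 4 (0.47 log units; beyond the scatter) is the only step at this position that passes beyond the scatter. Methoxy in place of bromo gives a 1.9-fold higher number from compound 2 to compound 4 (0.27 log units; within the scatter) and so does not separate those two groups, while iodo in place of chloro on an aromatic carbon, with methoxy held constant, gives a 1.2-fold higher number from compound 1 to compound 4 (0.07 log units; within the scatter) and does not separate those two either. Nothing among the available measurements explains the step from trifluoromethyl to methoxy. The compounds shown leave open whether an amine, a hydroxyl or a carboxylic acid at this position would stay close to compound 3 or to compound 4. They also leave open whether the trifluoromethyl to methoxy step holds with chloro in place of iodo.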